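This account rests on a few compounds, and the source may have more. Where it says the series, first, only, none or still open, it means among the compounds named here.

Measured compounds:
- compound 1 `O=C(NC(=S)NNc1ncnc2ccccc12)c1ccccc1F`: 2510 nM
- compound 2 `COc1cc2ncnc(NNC(=S)NC(=O)c3ccccc3Cl)c2cc1OC`: 3560 nM
- compound 3 `COc1cc2ncnc(NNC(=S)NC(=O)c3ccc(F)cc3)c2cc1OC`: 4530 nM

All three numbers come from a functional assay on KB cells (Homo sapiens) for cytotoxicity, read by MTT assay, with a stated time of 72 h; on this read-out higher numbers stand for weaker inhibition and lower numbers for stronger inhibition. Compound 1 gives the lowest of the three, but its gaps to compound 2 and to compound 3 both stay within the scatter, so none of the three can be set apart from the others. Compound 4 `O=C(NC(=S)NNc1ncnc2ccccc12)c1ccc(F)cc1` differs from compound 1 in one place: 4-fluorophenyl in place of 2-fluorophenyl on a carbonyl carbon. Among the measured compounds shown here, one measured step bears on this, since it also put 4-fluorophenyl onto the carbonyl carbon in place of another substituted phenyl: a 1.3-fold higher number from compound 2 to compound 3 (0.10 log units; within the scatter). That step stayed within the scatter, so no step beyond the scatter is expected here either. The expected step is a 1.2-fold higher number from compound 1 to compound 4 (0.08 log units; within the scatter). Compound 4 is therefore estimated at 3000 nM, with a range from 1500 nM to 6000 nM.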

Compound 4, half-maximal inhibitory concentration: 1870 nM
Beside the measured number, compound 4's estimate is 1.6-fold (0.21 log units) above it; low and high end bracket the measured number.
By their numbers in this assay, from the lowest: compounds 4, 1, 2 and 3 (each within the scatter of the next, the first and the last beyond it).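

Shifting the fluorine on the phenyl group at the carbonyl carbon, with 4-fluorophenyl in place of 2-fluorophenyl, gives a 1.3-fold lower number from compound 1 to compound 4 (0.13 log units; within the scatter) in this assay. Unlike the step from compound 2 to compound 3, which also exchanged chlorine for fluorine, this pair changes only where the fluorine sits on the ring, and that change does not set the two compounds apart. Nothing measured here offers an explanation for this result.

From the compounds shown here alone, whether a methoxy group, an amine or a carboxylic acid on this phenyl ring would move the number beyond the scatter remains open.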